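Tert-butyl amide replaces methoxyphenyl in a cytotoxicity set

A few compounds are considered here, and "the series" means these few. Any claim that something is new, unique, unknown or untested is made for them only; others in the source may bear on it.

compound 1, `COc1ccccc1NC(=O)c1c(NC(=O)C(F)(F)F)sc2c1CCCCC2`: > 50000 nM
compound 2, `CC(=O)Nc1sc2c(c1C(=O)OC(C)(C)C)CCCCC2`: > 50000 nM
compound 3, `COc1ccc(NC(=O)c2ccsc2NC(=O)C(F)(F)F)cc1`: > 50000 nM

Of the compounds shown here, three have been measured in an ADME assay on THP-1 cells (Homo sapiens) for cytotoxicity; a lower number here means that less compound is tolerated, a higher number that more compound is tolerated. Compound 1 gives only a limit there, > 50000 nM, and not a number. Compound 2 likewise gives a limit, > 50000 nM. Compound 3 also gives a limit, > 50000 nM. Compound 1 therefore stands where every value in this set stands, at the limit of > 50000 nM in this assay, at which 3 of the 3 values shown sit, and nothing separates it from compound 2 or compound 3 on these numbers.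

The next compound, compound 4, `CC(C)(C)NC(=O)c1c(NC(=O)C(F)(F)F)sc2c1CCCCC2`, has not yet been measured in this assay. It differs from compound 1 in one place: tert-butyl in place of 2-methoxyphenyl on an amide-type nitrogen. Within the data shown here, no pair of measured compounds differs in a single place, so there is no measured step to compare this change against; all that is known is that every measured compound, whatever its amide substituent or ester, is tolerated up to the limit.

On that basis the step from compound 1 to compound 4 is expected to be a number no higher from compound 1 to compound 4 (the limit leaves the size open), that is, nothing beyond the usual scatter, with the most likely outcome again a limit. Compound 4 is accordingly expected to give about 50000 nM in this assay, within a range from 25000 nM to 100000 nM.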

Compound 4, half-maximal cytotoxic concentration: > 50000 nM
Compound 4 was reported as a limit; the forecaster's own chance of this, stated with the estimate: 85%; the middle value lies on the limit itself.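

In this assay compound 4 gives > 50000 nM, a limit and not a number. Compound 1 also gives only a limit, so no step can be read from compound 1 to compound 4: the limit of > 50000 nM in this assay, at which 4 of the 4 values shown sit. The compounds shown leave open at what concentration, if any, each of them becomes cytotoxic to these cells.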